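Carbamate Selenocyanates: Fluoro to Methyl on the Aryl Ester

A few compounds are considered here, and "the series" means these few. Any claim that something is new, unique, unknown or untested is made for them only; others in the source may bear on it.

Compound 1 `COc1ccc(OC(=O)Nc2ccc([Se]C#N)cc2)cc1` gives 4500 nM in an ADME assay on 184B5 cells (Homo sapiens) for cytotoxicity, read by MTT assay, with a stated time of 72 h; a higher number here means a weaker inhibitor of growth, a lower number a stronger inhibitor of growth.
Compound 2 `CC(C)COC(=O)Nc1ccc([Se][Se]c2ccc(NC(=O)OCC(C)C)cc2)cc1` gives 5500 nM in this assay.
Compound 3 `N#C[Se]c1ccc(NC(=O)Oc2ccc(F)cc2)cc1` gives 6900 nM in this assay.

The three measured compounds lie close together in this assay; compound 3 is separated from neither compound 2 nor compound 1 by more than the scatter, so no one of them stands apart. Within the data shown here, the only step that alters a single place is a 1.5-fold higher number from compound 1 to compound 3 (0.19 log units; within the scatter), which exchanges one small group on the aryl ester for another and leaves the number essentially where it was.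

Compound 4 `Cc1ccc(OC(=O)Nc2ccc([Se]C#N)cc2)cc1` differs from compound 3 by methyl in place of fluoro on an aromatic carbon. Among the measured compounds shown here, this is again an exchange of one small group at the same position of the aryl ester, and the one comparable step from compound 1 to compound 3 stayed within the scatter. The expectation is therefore that compound 4 shows no step beyond the scatter, a 1.2-fold lower number from compound 3 to compound 4 (0.06 log units; within the scatter). Compound 4 is estimated at 6000 nM in this assay, with a range from 3000 nM to 12000 nM.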

Compound 4, concentration for 50% growth inhibition: 4400 nM
Compound 4: middle estimate off by 1.4-fold (0.13 log units), on the high side; low and high end bracket the measured number.
By their numbers in this assay, from the lowest: compounds 4, 1, 2 and 3 (each within the scatter of the next).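

With compound 4, this position on an aromatic carbon has carried three small groups. In this assay, methyl in place of fluoro gives a 1.6-fold lower number from compound 3 to compound 4 (0.20 log units; within the scatter) and methyl in place of methoxy gives a 1.0-fold lower number from compound 1 to compound 4 (0.01 log units; within the scatter) as the second comparison. Fluoro, methoxy and methyl therefore all lie within the scatter of one another here, so this position, para to a large group, has so far tolerated each exchange without a step beyond the scatter, and no measurement at hand accounts for that.

As far as these compounds go, it remains open whether a different kind of group at this position, such as an amine, a carboxylic acid or a longer chain, would move the number beyond the scatter. Also open, from the compounds shown here alone, is whether these three compounds would stay this close together on another cell line.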